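A few compounds are considered here, and "the series" means these few. Any claim that something is new, unique, unknown or untested is made for them only; others in the source may bear on it.

Compound 1 `CCCCCCCCn1cc(CO[C@H]2CC(=O)[C@@H]3OC[C@H]2O3)nn1`: > 50000 nM
Compound 2 `O=C1C[C@H](OCc2cn(-c3ccc([N+](=O)[O-])cc3)nn2)[C@H]2CO[C@@H]1O2`: 24800 nM

In a functional assay on MDA-MB-231 cells (Homo sapiens) for cytotoxicity, read by MTT assay, with a stated time of 48 h (on this read-out higher numbers stand for weaker inhibition and lower numbers for stronger inhibition), compound 1 gives > 50000 nM, which is a limit of the assay rather than a number. Compound 1 thus stands at the limit of > 50000 nM in this assay, at which 1 of the 2 values shown sits. In this assay compound 2 gives 24800 nM. Compound 3 `CCCCn1cc(CO[C@H]2CC(=O)[C@@H]3OC[C@H]2O3)nn1` is not yet measured and differs from compound 1 by hydrogen in place of butyl on a saturated chain carbon, four bonds along the chain from an aromatic nitrogen. Going by the values given here, no step between two measured compounds is available to calibrate this change. A step of about an at least 1.2-fold lower number from compound 1 to compound 3 (0.09 log units; that floor lies within the scatter) is expected, a modest move toward stronger inhibition while remaining weak. For compound 3 the estimate is 40000 nM, with a range from 15000 nM to 100000 nM.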

Compound 3, half-maximal inhibitory concentration: 27900 nM
Compound 3: the middle estimate sits 1.4-fold (0.16 log units) above what was measured, and the stated range covers the measured number.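

Putting hydrogen in place of butyl on this chain gives a value that can be read as a number in this assay, with an at least 1.7-fold lower number from compound 1 to compound 3 (0.25 log units; that floor lies within the scatter). Shortening the chain is therefore not shown to strengthen inhibition, and the true size of the step stays unknown because one end of it is a limit: the limit of > 50000 nM in this assay, at which 1 of the 3 values shown sits. The shorter chain does show that inhibition, though weak, is still measurable at this position.

As far as these compounds go, how an ethyl chain or a chain carrying an amine or a carboxylic acid would behave here remains open.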